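This account rests on a few compounds, and the source may have more. Where it says the series, first, only, none or still open, it means among the compounds named here.

Compound 2 `Nc1ccc(S(=O)(=O)N2CCN(c3ncc(C(O)(C(F)(F)F)C(F)(F)F)cc3-c3cccc(F)c3)CC2)cn1` is one of three compounds compared in an ADME assay (liver) for metabolic stability, with Liver microsome (Rattus norvegicus) as the target, using microsomes and NADPH, with a stated time of 30 min, tested at 1 uM; on this read-out lower numbers stand for slow clearance and higher numbers for fast clearance. In that assay compound 2 gives 52 mL.min-1.g-1, the second highest of the three numbers. Compound 1 `Nc1ccc(S(=O)(=O)N2CCN(c3ncc(C(O)(C(F)(F)F)C(F)(F)F)cc3C#CC3CC3)CC2)cn1` gives 67 mL.min-1.g-1, and the step of a 1.3-fold lower number from compound 1 to compound 2 (0.11 log units; within the scatter) lies within the scatter. Compound 3 `Nc1ccc(S(=O)(=O)N2CCN(c3ncc(C(O)(C(F)(F)F)C(F)(F)F)cc3-c3cncc(F)c3)CC2)cn1` gives 19 mL.min-1.g-1, and the step of a 2.7-fold lower number from compound 2 to compound 3 (0.44 log units; beyond the scatter) is beyond the scatter; likewise a 3.5-fold lower number from compound 1 to compound 3 (0.55 log units; beyond the scatter).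

Compound 4 `Cc1nc2cc(-c3cc(C(O)(C(F)(F)F)C(F)(F)F)cnc3N3CCN(S(=O)(=O)c4ccc(N)nc4)CC3)ccc2o1` has not yet been measured. It differs from compound 2 in one place: 2-methyl-1,3-benzoxazol-5-yl in place of 3-fluorophenyl on an aromatic carbon.

Of the measured steps, only the swap of one aromatic ring for another on the same carbon bears on this change. Putting a ring with a hetero atom in place of the 3-fluorophenyl lowered the number in the step from compound 2 to compound 3, while the 3-fluorophenyl itself sat within the scatter of compound 1. The new ring again brings hetero atoms and acceptors, so a modest fall is expected, with the extra size and the methyl leaving room for doubt. Compound 4 is therefore expected to give 35 mL.min-1.g-1, roughly between 15 mL.min-1.g-1 and 80 mL.min-1.g-1, a step of a 1.5-fold lower number from compound 2 to compound 4 (0.17 log units; within the scatter).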

Compound 4, intrinsic clearance in microsomes: 99 mL.min-1.g-1
Compound 4: the middle estimate sits 2.8-fold (0.45 log units) below what was measured, outside the stated range (above it).
By their numbers in this assay, from the lowest: compound 3; then compounds 2, 1 and 4 (each within the scatter of the next).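

In this assay, a ring with hetero atoms at this position does not always go with a low number: 2-methyl-1,3-benzoxazol-5-yl in place of 3-fluorophenyl gives a 1.9-fold higher number from compound 2 to compound 4 (0.28 log units; within the scatter) and in place of 2-cyclopropylethynyl gives a 1.5-fold higher number from compound 1 to compound 4 (0.17 log units; within the scatter) and so compound 4 cannot be told apart from compound 1 or compound 2. Among these compounds only compound 3 stands apart, as the step of a 5.2-fold higher number from compound 3 to compound 4 (0.72 log units; beyond the scatter) shows, so the low number seen with 5-fluoropyridin-3-yl does not carry over to this larger ring. Nothing shown here explains these differences.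

The compounds shown leave open whether a plain pyridin-3-yl, without the fluorine, or a benzoxazol-5-yl without the methyl would give a number nearer that of compound 3 or that of compound 4. They also do not tell how a saturated amine such as morpholine would behave on the same carbon.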